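Cytotoxicity Limit Carried from Compound 2 to Compound 3

A few compounds are considered here, and "the series" means these few. Any claim that something is new, unique, unknown or untested is made for them only; others in the source may bear on it.

Compound 2 `Cc1scnc1COc1cc(Cl)cc(-c2cc(-c3c[nH]c(=O)[nH]c3=O)cn(-c3cccnc3)c2=O)c1`: > 100000 nM
Compound 1 `Cc1ocnc1COc1cc(Cl)cc(-c2cc(-c3ccccc3C#N)cn(-c3cccnc3)c2=O)c1`: "not determined" (no result reported)

In an ADME assay on Vero C1008 cells (Chlorocebus sabaeus) for cytotoxicity, read by MTT assay, with a stated time of 72 h (a higher number here means that more compound is tolerated, a lower number that less compound is tolerated), compound 1 has no result, its entry reading "not determined" (no result reported). Compound 2 reaches only a limit of this assay: compound 2 gives > 100000 nM, a limit and not a number. Compound 2 therefore sits at the limit of > 100000 nM in this assay, at which 1 of the 2 values shown sits. Compound 3 `O=c1[nH]cc(-c2cc(-c3cc(Cl)cc(OCc4scnc4C(F)(F)F)c3)c(=O)n(-c3cccnc3)c2)c(=O)[nH]1` differs from compound 2 by a group of 9 heavy atoms (4 carbon, 1 nitrogen, 3 fluorine, 1 sulfur; one five-membered aromatic ring with 2 hetero atoms) in place of a group of 6 heavy atoms (4 carbon, 1 nitrogen, 1 sulfur; one five-membered aromatic ring with 2 hetero atoms), on a saturated chain carbon bound to an oxygen on an aromatic ring. For the measured compounds named here, no measured step covers this change, so no shift beyond the usual scatter is expected. The step of a number no higher from compound 2 to compound 3 (the limit leaves the size open) is estimated to be negligible. Compound 3 is expected to give 100000 nM, within 30000 nM to 300000 nM, most likely again reported only as a limit.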

Compound 3, half-maximal cytotoxic concentration: > 100000 nM
Compound 3: a limit, no number (the forecaster's own chance of this, stated with the estimate: 70%); the middle value lies on the limit itself.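

In this assay, for the compounds shown here, compound 2 and compound 3 each give only a limit, not a number, so no step between them can be read. The compounds shown leave open whether replacing the 5-methyl-1,3-thiazol-4-yl group shifts the tolerated concentration at all.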